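The source may hold more compounds than are shown below. What is called first, only, known or untested is meant among the compounds shown, and "the series" means these compounds.

The study concerns a small set of closely related compounds tested for cytotoxicity. In a functional assay on BT-549 cells (Homo sapiens) for cytotoxicity, read by sulforhodamine B assay, with a stated time of 48 h (a higher number here means that more compound is tolerated, a lower number that less compound is tolerated), compound 1 `ClCc1cccc(Cn2cnc3ncnc(Cl)c32)c1` gives 63100 nM. Compound 2 `ClCc1ccccc1Cn1cnc2ncnc(Cl)c21` is built from the same atoms joined differently; in this assay compound 2 gives 25100 nM, and the difference between the two cores is not broken down here. Compound 3 `ClCc1cccc(Cn2cnc3nc(Cl)nc(Cl)c32)c1` gives 4160 nM in this assay, the lowest of the three numbers. Compound 3 arises from compound 1 by a single change, (chloro in place of hydrogen on an aromatic carbon), and this change made the step of a 15-fold lower number from compound 1 to compound 3 (1.18 log units; beyond the scatter). Among the three, compound 2 stands second highest; its nearest neighbour is compound 1, whose number is higher, and its furthest is compound 3, whose number is lower.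

Compound 4 `ClCc1ccccc1Cn1cnc2nc(Cl)nc(Cl)c21` remains to be measured in this assay. It differs from compound 2 by chloro in place of hydrogen on an aromatic carbon, and the place is described in the same words as for the change from compound 1 to compound 3, so the same change is here made on the core of compound 2. Going by the values given here, only one instance of the change has been measured, the step of a 15-fold lower number from compound 1 to compound 3 (1.18 log units; beyond the scatter), and on that single instance the expectation rests: the step from compound 2 to compound 4 is expected to be about a 13-fold lower number from compound 2 to compound 4 (1.10 log units; beyond the scatter) in this assay. Because compound 2 gives 25100 nM, compound 4 is estimated at 2000 nM in this assay, expected to fall between 700 nM and 6000 nM.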

Compound 4, concentration lethal to 50% of the cells: 7070 nM
For compound 4 the middle estimate is 3.5-fold (0.55 log units) below the measured one; the measured number lies above the stated range.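

In this assay, the added chloro also lowers the number on the core of compound 2, with a 3.6-fold lower number from compound 2 to compound 4 (0.55 log units; beyond the scatter), so the direction of the change is the same on both cores shown. The size of the step, however, did not carry over from one core to the other: the same change on two cores in this assay, a 15-fold lower number (1.18 log units; beyond the scatter) from compound 1 to compound 3 and a 3.6-fold lower number (0.55 log units; beyond the scatter) from compound 2 to compound 4, 4.3-fold (0.63 log units) apart, beyond the scatter of two such steps With only these two pairs, the series shows that a step measured on one core gives the direction on the other but not a reliable size, and it does not show which feature of the two cores, built from the same atoms joined differently, sets the gap or how a further core would behave.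

The compounds shown carry only hydrogen or chloro on this aromatic carbon between two ring nitrogen atoms, so it remains open whether an amine, a methoxy group or a longer chain in that place would lower the number, and whether the dependence on the core would appear with those groups too. Going by these compounds, it also remains open whether the two steps would keep their direction and their difference in size in cells other than those of this single assay.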